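A few compounds are considered here, and "the series" means these few. Any claim that something is new, unique, unknown or untested is made for them only; others in the source may bear on it.

Compound 1 `CCc1ccccc1NS(=O)(=O)c1ccc(N2CCNC2=O)cc1` was examined in a functional assay on M21 cells (Homo sapiens) for antiproliferative activity, read by sulforhodamine B assay, with a stated time of 48 h (a lower number here means a stronger inhibitor, a higher number a weaker inhibitor), where compound 1 gives 180 nM. Among the three measured compounds this is the second highest number. For the measured compounds named here, its nearest neighbour is compound 3 `O=C1NCCN1c1ccc(S(=O)(=O)Nc2cccc(Oc3ccccc3)c2)cc1`, which in this assay gives 83 nM; no single-point step links these two, so their values are simply set side by side. Furthest away is compound 2 `CCc1ccc(NS(=O)(=O)c2ccc(N3CCNC3=O)cc2)cc1`, which in this assay gives 480 nM. Going by the values given here, the one measured step that bears on the present question is a 2.7-fold higher number from compound 1 to compound 2 (0.43 log units; beyond the scatter), showing that where the ethyl group sits on the phenyl attached to the sulfonamide nitrogen shifts the number by a modest amount. Compound 4 `O=C1NCCN1c1ccc(S(=O)(=O)Nc2ccccc2)cc1` differs from compound 1 by hydrogen in place of ethyl on an aromatic carbon. Among the compounds with values here, no measured step removes the ethyl group outright, so the outcome is uncertain, but because a 2.7-fold higher number from compound 1 to compound 2 (0.43 log units; beyond the scatter) was modest and upward, losing the ethyl group of the 2-ethylphenyl is expected to raise the number somewhat as well. The change is therefore estimated as a 2.2-fold higher number from compound 1 to compound 4 (0.35 log units; beyond the scatter). Compound 4 is expected to give 400 nM, with a range from 150 nM to 1100 nM.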

Compound 4, half-maximal inhibitory concentration: 200 nM
Compound 4: middle estimate off by 2.0-fold (0.30 log units), on the high side; the measured number falls inside the stated range.
By their numbers in this assay, from the lowest: compound 3; then compounds 1 and 4 (each within the scatter of the next); then compound 2.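

In this assay, the ethyl group of compound 1 can give way to hydrogen with a 1.1-fold higher number from compound 1 to compound 4 (0.05 log units; within the scatter), so at this place on the ring ethyl and hydrogen cannot be told apart, whereas taking the ethyl group from compound 2 gives a 2.4-fold lower number from compound 2 to compound 4 (0.38 log units; beyond the scatter), which means the ethyl group counts in one compound and not in the other. Replacing phenoxy with hydrogen gives a 2.4-fold higher number from compound 3 to compound 4 (0.38 log units; beyond the scatter), so among the groups shown only phenoxy gives a lower number than plain phenyl. Nothing measured here accounts for any of these steps.

From the compounds shown here alone, it remains open whether a longer chain such as butyl, or a methoxy group, a chlorine or an amine, would also stay level with hydrogen at this place. Going by these compounds, whether a phenoxy group placed there would match compound 3 is equally open.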